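Trifluoromethyl to cyclopropyl on the aryl ring

The source may hold more compounds than are shown below. What is called first, only, known or untested is meant among the compounds shown, and "the series" means these compounds.

In an ADME assay (liver) for metabolic stability, with Liver microsome (Canis lupus familiaris) as the target, read by LC-MS, using microsomes, with a stated time of 30 min, tested at 4 uM (a higher number here means that more of the compound is left, a lower number that less of the compound is left), compound 1 `CCN1CCN(c2nc(C)nc3c2nc(-c2ccccc2Cl)n3CCOC)CC1` gives 86%, compound 2 `CCN1CCN(c2nc(C)nc3c2nc(-c2ccccc2Cl)n3CC2CCOCC2)CC1` gives 76%, and compound 3 `Cc1nc(N2CCN(C)CC2)c2nc(-c3ccccc3C(F)(F)F)n(C3CCOCC3)c2n1` gives 61%, the lowest of the three and beyond the scatter from both others. Compound 4 `Cc1nc(N2CCN(C)CC2)c2nc(-c3ccccc3C3CC3)n(C3CCOCC3)c2n1` differs from compound 3 by cyclopropyl in place of trifluoromethyl on an aromatic carbon. Within the data shown here, the only measured step, a number 10 percentage points lower from compound 1 to compound 2 (within the scatter), lies within the scatter and concerns a saturated chain carbon bound to an aromatic nitrogen, so no measured step bears directly on this change. Only a small step within the scatter is therefore expected, estimated as a number 6 percentage points lower from compound 3 to compound 4 (within the scatter). In this assay the estimate for compound 4 is 55%, with an expected range of 35% to 72%.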

Compound 4, percent of the compound remaining: 69%
Compound 4: middle estimate off by 14 percentage points, on the low side; measured number inside the range.
By their numbers in this assay, from the lowest: compounds 3, 4, 2 and 1 (each within the scatter of the next, the first and the last beyond it).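

In this assay, among these compounds, cyclopropyl in place of trifluoromethyl gives a number 8 percentage points higher from compound 3 to compound 4 (within the scatter) as the only measured step on this aromatic carbon, ortho to a large group. At this position, the read-out therefore does not separate these two groups. Nothing available explains this result.

As far as these compounds go, whether a nitrile, a methoxy group or an ethyl group on this carbon would stand apart from these two remains open. Also open, from the compounds shown here alone, is whether the same exchange gives a similar step when methoxymethyl sits on the saturated chain.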